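This account rests on a few compounds, and the source may have more. Where it says the series, first, only, none or still open, it means among the compounds named here.

Compound 1 `Cc1cc(C)c(NC(=O)N(Cc2ccc(-c3ccn(C)n3)cc2)C2CCCCCC2)c(C)c1` gives 44 nM in an assay on microsomes from intestine for inhibition of acyl-CoA:cholesterol acyltransferase (Oryctolagus cuniculus); on this read-out lower numbers stand for stronger inhibition and higher numbers for weaker inhibition. Compound 2 `Cc1cc(C)c(NC(=O)N(Cc2cccc(-c3ccn(C)n3)c2)C2CCCCCC2)c(C)c1` shares the same atoms joined differently, and how the two cores differ is not broken down here; in this assay compound 2 gives 42 nM, and the two values lie within the usual scatter of each other. Compound 3 `Cc1cc(C)c(NC(=O)N(Cc2ccc(-c3ccnn3C)cc2)C2CCCCCC2)c(C)c1` arises from compound 1 by 1-methyl-1H-pyrazol-5-yl in place of 1-methyl-1H-pyrazol-3-yl on an aromatic carbon; in this assay compound 3 gives 24 nM, so that a 1.8-fold lower number from compound 1 to compound 3 (0.26 log units; within the scatter).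

Compound 4 `Cc1cc(C)c(NC(=O)N(Cc2cccc(-c3ccnn3C)c2)C2CCCCCC2)c(C)c1` has not yet been measured. It arises from compound 2 by 1-methyl-1H-pyrazol-5-yl in place of 1-methyl-1H-pyrazol-3-yl on an aromatic carbon. Within the data shown here, this is the same kind of change as the one from compound 1 to compound 3, but not the same: there the group sits para to a large group, here meta to a large group.

Resting on the step from compound 1 to compound 3 and on the value of compound 2, a similar small step is expected, namely a 1.5-fold lower number from compound 2 to compound 4 (0.18 log units; within the scatter). For compound 4 in this assay the estimated value is 28 nM, expected to fall between 14 nM and 56 nM.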

Compound 4, half-maximal inhibitory concentration: 35 nM
Compound 4: the middle estimate sits 1.3-fold (0.10 log units) below what was measured, within the range that was stated.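

Placing 1-methyl-1H-pyrazol-5-yl in place of 1-methyl-1H-pyrazol-3-yl on an aromatic carbon, meta to a large group, gives a 1.2-fold lower number from compound 2 to compound 4 (0.08 log units; within the scatter) in this assay. Set beside the earlier step, the result gives no sign that the change behaves differently on the two cores: the same change on two cores in this assay, a 1.8-fold lower number (0.26 log units; within the scatter) from compound 1 to compound 3 and a 1.2-fold lower number (0.08 log units; within the scatter) from compound 2 to compound 4, 1.5-fold (0.18 log units) apart, within the scatter of two such steps. This shows that, on these two cores, the exchange of one pyrazole group for the other leaves the read-out within the usual scatter, but with both steps inside that scatter it does not show that the change has a real effect of its own, and two cores cannot establish a rule for the whole series.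

The compounds shown carry only these two methylpyrazole groups, so they leave open how a carboxylic acid or a dimethylamino group at the same place would read in this assay. From the compounds shown here alone, whether the exchange stays as small on any further core also remains open.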